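The source may report more compounds than this note shows. Statements on the series, on what has been measured and on what is new or still open speak of the compounds shown alone.

Series notes on cytotoxicity. Compound 1 `COc1nc(-c2ccc(OC(F)(F)F)cc2)ccc1[C@@H](c1ccccc1)[C@@](O)(CCN(C)C)c1cccc2ccccc12` carries 4-(trifluoromethoxy)phenyl on the shared core. In a toxicity assay on Vero cells (Chlorocebus sabaeus) for cytotoxicity (on this read-out higher numbers stand for lower toxicity in this test and lower numbers for higher toxicity in this test), compound 1 reaches only the assay limit > 50 ug/mL, not a number. Compound 2 `COc1nc(-c2cccc(F)c2)ccc1[C@@H](c1ccccc1)[C@@](O)(CCN(C)C)c1cccc2ccccc12` has 3-fluorophenyl in that place. In this assay compound 2 likewise stops at the limit > 50 ug/mL. The step that the two limits leave unreadable from compound 1 to compound 2 cannot be read, so compound 2 stands at the same limit as compound 1 with no number for either. The one firm feature of the measured data is the limit of > 50 ug/mL in this assay, at which 2 of the 2 values shown sit.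

Compound 3 `COc1nc(C2CCOCC2)ccc1[C@@H](c1ccccc1)[C@@](O)(CCN(C)C)c1cccc2ccccc12` differs from compound 2 by oxan-4-yl in place of 3-fluorophenyl on an aromatic carbon. Among the measured compounds shown here, the only measured step concerns a different exchange and is unreadable, so it supplies no size to carry over, and the two measured values show nothing beyond the limit. The expected step that the limit leaves unreadable from compound 2 to compound 3 in this assay is accordingly of no readable size, most likely ending again at the limit. Compound 3 is estimated at 60 ug/mL, within 30 ug/mL to 150 ug/mL.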

Compound 3, half-maximal cytotoxic concentration: > 50 ug/mL
Compound 3 was reported as a limit (the forecaster's own chance of this, stated with the estimate: 80%); the middle value is on the limit's open side.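

In this assay compound 3 gives > 50 ug/mL, again a limit and not a number, so the steps linking compound 3 with compound 1 and compound 2 cannot be read: the limit of > 50 ug/mL in this assay, at which 3 of the 3 values shown sit.

The compounds shown leave open at what concentration compound 1, compound 2 or compound 3 would reach half-maximal cytotoxicity, and whether the three differ at all.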